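Swapping Tert-butyl for (4-Chlorophenoxy)methyl

The source may report more compounds than this note shows. Statements on the series, on what has been measured and on what is new or still open speak of the compounds shown alone.

Three measured compounds share one core and differ only in a side group. In an ADME assay on Vero cells (Chlorocebus sabaeus) for cytotoxicity, read by MTT assay, with a stated time of 48 h (on this read-out higher numbers stand for lower toxicity in this test and lower numbers for higher toxicity in this test), compound 1 `CC(NC(=O)c1ccc([N+](=O)[O-])o1)c1ccccc1` gives 24000 nM. Compound 2 `O=C(Nc1ccc2ccccc2c1)c1ccc([N+](=O)[O-])o1` reaches only the limit of this assay, > 150000 nM. Compound 3 `CC(C)(C)c1ccc(C(C)(C)NC(=O)c2ccc([N+](=O)[O-])o2)cc1` likewise stops at a limit, > 150000 nM, so compound 3 stands at the limit of > 150000 nM in this assay, at which 2 of the 3 values shown sit, rather than at a measured number.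

Compound 4 `CC(C)(NC(=O)c1ccc([N+](=O)[O-])o1)c1ccc(COc2ccc(Cl)cc2)cc1` differs from compound 3 by (4-chlorophenoxy)methyl in place of tert-butyl on an aromatic carbon. Among the compounds with values here, no measured pair shows this exchange, so its effect is unknown; the expectation is a drift toward higher toxicity, perhaps no larger than the usual scatter. Compound 4 is therefore expected near 80000 nM, between 20000 nM and 200000 nM. The expected change, an at least 1.8-fold lower number from compound 3 to compound 4 (0.27 log units; that floor lies within the scatter), is small.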

Compound 4, half-maximal cytotoxic concentration: 120000 nM
For compound 4 the middle estimate is 1.5-fold (0.18 log units) below the measured one; the range from low to high includes it.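

Compound 4 gives a measured number at this position, where compound 3 offered only a limit. The exchange adds an aromatic ring and an oxygen acceptor on this aromatic carbon and amounts in this assay to an at least 1.2-fold lower number from compound 3 to compound 4 (0.09 log units; that floor lies within the scatter), so even this larger group need not bring a clear rise in toxicity. The true size of the step cannot be fixed, and limits still mark this small set: the limit of > 150000 nM in this assay, at which 2 of the 4 values shown sit.

As far as these compounds go, what an amine or a carboxylic acid on this aromatic carbon would do stays open.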